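Extending the thioether of compound 3 with a naphthoyl group

The source may report more compounds than this note shows. Statements on the series, on what has been measured and on what is new or still open speak of the compounds shown alone.

Compound 3 `COc1cc(-c2nnc(SC)n2-c2ccc(N(C)C)cc2)cc(OC)c1OC` carries dimethylamino where compound 1 `COc1ccc(-n2c(SC)nnc2-c2cc(OC)c(OC)c(OC)c2)cc1` carries methoxy. In a functional assay on PC-3 cells (Homo sapiens) for inhibition, read by MTT assay, with a stated time of 48 h (on this read-out higher numbers stand for weaker inhibition and lower numbers for stronger inhibition), compound 3 gives only a limit of the assay, > 60000 nM. Compound 1 likewise gives only a limit, > 60000 nM. The step that the two limits leave unreadable from compound 1 to compound 3 is therefore not readable; both values sit at the limit of > 60000 nM in this assay, at which 2 of the 3 values shown sit. Compound 2 `COc1ccc(NC(=O)CSc2nnc(-c3cc(OC)c(OC)c(OC)c3)n2-c2ccc(OC)cc2)cc1` gives 25800 nM, and the step of an at least 2.3-fold lower number from compound 1 to compound 2 (0.36 log units; beyond the scatter) shows that a substituent entering on the saturated chain carbon bound to a sulfur moves the number out of the limit. Compound 4 `COc1cc(-c2nnc(SCC(=O)c3ccc4ccccc4c3)n2-c2ccc(N(C)C)cc2)cc(OC)c1OC` differs from compound 3 by (naphthalen-2-yl)carbonyl in place of hydrogen on a saturated chain carbon bound to a sulfur. Among the measured compounds shown here, the only bearing step is that from compound 1 to compound 2, so a lower number is expected for compound 4, a step of about an at least 2.4-fold lower number from compound 3 to compound 4 (0.38 log units; beyond the scatter). Compound 4 is thus estimated at 25000 nM, within 8000 nM to 60000 nM.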

Compound 4, half-maximal inhibitory concentration: 18100 nM
Estimate against measurement, compound 4: 1.4-fold (0.14 log units) above, and the stated range covers the measured number.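

Placing (naphthalen-2-yl)carbonyl on the saturated chain carbon bound to a sulfur gives an at least 3.3-fold lower number from compound 3 to compound 4 (0.52 log units; beyond the scatter) in the dimethylamino compound, so the move off the limit is no longer confined to methoxy and (4-methoxyphenyl)carbamoyl. The size of this step remains only a bound, since the value of compound 3 is a limit: the limit of > 60000 nM in this assay, at which 2 of the 4 values shown sit.

The two substituents stand on different partners, so their order and the effect of methoxy against dimethylamino with a substituent present cannot be read. From the compounds shown here alone, whether a carboxylic acid, an amine or a longer chain on this carbon lowers the number further remains open.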